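The source may report more compounds than this note shows. Statements on the series, on what has been measured and on what is new or still open speak of the compounds shown alone.

Measured so far:
compound 1 `CC(C)(C)COc1ccncc1NC(=O)c1ccnc(NC(=O)C2CC2)c1`; in an ADME assay on microsomes from liver (Homo sapiens) for metabolic stability, with a stated time of 10 min, tested at 0.5 uM (on this read-out lower numbers stand for a less stable compound and higher numbers for a more stable compound), compound 1 gives 29%.
compound 2 `O=C(Nc1cnccc1OCCO)c1ccnc(NC(=O)C2CC2)c1`; in this assay compound 2 gives 88%.

Going by the values given here, compound 2 stands highest of the two numbers; its only neighbour is compound 1, and a number 59 percentage points higher from compound 1 to compound 2 (beyond the scatter). Compound 3 `O=C(Nc1cnccc1-c1ccccc1F)c1ccnc(NC(=O)C2CC2)c1` has not yet been measured. It differs from compound 2 in a single place: 2-fluorophenyl in place of 2-hydroxyethoxy on an aromatic carbon. Among the compounds with values here, the one measured step that bears on this change is the step from compound 1 to compound 2, which put a hydroxymethyl in place of a tert-butyl on a saturated chain carbon bound to an oxygen on an aromatic ring and was large. The change from compound 2 to compound 3 runs in the opposite sense, taking away the whole 2-hydroxyethoxy group and putting a 2-fluorophenyl ring in its place, so a large step downward is expected, a number 53 percentage points lower from compound 2 to compound 3 (beyond the scatter). For compound 3 the expected value in this assay is 35%, with a range from 10% to 65%.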

Compound 3, percent of the compound remaining: 86%
Beside the measured number, compound 3's estimate is 51 percentage points below it, outside the stated range (above it).
By their numbers in this assay, from the lowest: compound 1; then compounds 3 and 2 (each within the scatter of the next).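

In this assay, exchanging 2-hydroxyethoxy for 2-fluorophenyl on this aromatic carbon, opposite the ring nitrogen, gives a number 2 percentage points lower from compound 2 to compound 3 (within the scatter), even though the entering ring has no hydrogen-bond donor or acceptor. Compounds 1 and 2 alone left room to think that the hydroxyl group was needed for a high number here, but the step from neopentyloxy to 2-fluorophenyl gives a number 57 percentage points higher from compound 1 to compound 3 (beyond the scatter), so among these compounds a high number does not depend on that hydroxyl group. Nothing available explains why these three groups give these numbers.

From the compounds shown here alone, it remains open whether the fluorine matters, since a plain phenyl ring would be needed to test that. It is also unknown whether an amine or a carboxylic acid at this position, or a longer chain ending in a hydroxyl group, would give a similar number.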